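This account rests on a few compounds, and the source may have more. Where it says the series, first, only, none or still open, it means among the compounds named here.

Compound 1 `O=C(/C=C/c1coc2cc(O)ccc2c1=O)NCc1ccccc1`: > 100000 nM
Compound 2 `COc1ccc2c(=O)c(/C=C/C(=O)NCc3ccc(F)cc3)coc2c1`: > 100000 nM

Both entries are limits in a functional assay on A549 cells (Homo sapiens) for inhibition, read by MTT assay, with a stated time of 48 h (a higher number here means a weaker inhibitor, a lower number a stronger inhibitor), not numbers. Going by the values given here, compound 2 has only the limit > 100000 nM, and the series so far offers (the limit of > 100000 nM in this assay, at which 2 of the 2 values shown sit). Compound 3 `O=C(/C=C/c1coc2cc(O)ccc2c1=O)NCc1ccc(F)cc1` differs from compound 2 by hydrogen in place of methyl on an oxygen on an aromatic ring, methoxy to hydroxy. Among the compounds with values here, no measured step is available to size this change, so no step beyond the scatter is expected in this assay. The estimated step of a number no higher from compound 2 to compound 3 (the limit leaves the size open) is expected to stay within that scatter. For compound 3 the expected value is 100000 nM, with an estimated range of 50000 nM to 200000 nM.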

Compound 3, half-maximal inhibitory concentration: > 100000 nM
Compound 3: a limit, no number (the forecaster's own chance of this, stated with the estimate: 85%); the middle value lies on the limit itself.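

Compound 3 gives a limit, not a number, and its comparisons with compound 1 and compound 2 yield no readable step. The compounds shown leave open whether methoxy to hydroxy, or fluoro in place of hydrogen, alters inhibition at all.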